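Adding a methyl to the nitrogen of compound 3

A few compounds are considered here, and "the series" means these few. Any claim that something is new, unique, unknown or untested is made for them only; others in the source may bear on it.

Measured in a functional assay on HCT-8 cells (Homo sapiens) for antiproliferative activity, read by MTT assay, with a stated time of 48 h; on this read-out lower numbers stand for stronger inhibition and higher numbers for weaker inhibition
Compound 1 `COc1ccc2c(/C=C/C(=O)c3cc(OC)c(OC)c(SC)c3)c[nH]c2c1` gives 138 nM
Compound 2 `COc1cc(C(=O)/C=C/c2c[nH]c3ccccc23)cc([N+](=O)[O-])c1OC` gives 1390 nM
Compound 3 `COc1cc(C(=O)/C=C/c2c[nH]c3ccccc23)cc(SC)c1OC` gives 167 nM

Compound 3 sits close to one relative and far from the other: the data show a 1.2-fold higher number from compound 1 to compound 3 (0.08 log units; within the scatter) and also an 8.3-fold lower number from compound 2 to compound 3 (0.92 log units; beyond the scatter) on this scale. Among the compounds with values here, compound 4 `COc1cc(C(=O)/C=C/c2cn(C)c3ccccc23)cc(SC)c1OC` brings methyl in place of hydrogen on an aromatic nitrogen as its only change, methyl in place of hydrogen on an aromatic nitrogen. Neither measured step touches that nitrogen, so both offer only a rough sense of size: one stayed within the scatter, the other was modest. No step beyond the scatter is therefore expected in this assay for this change. The estimate amounts to a 1.4-fold lower number from compound 3 to compound 4 (0.14 log units; within the scatter) as the expected outcome. Compound 4 is estimated at 120 nM with an expected range of 30 nM to 450 nM overall.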

Compound 4, half-maximal inhibitory concentration: 210 nM
Estimate against measurement, compound 4: 1.8-fold (0.24 log units) below; measured number inside the range.
By their numbers in this assay, from the lowest: compounds 1, 3 and 4 (each within the scatter of the next); then compound 2.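

Within the data shown here, all the earlier compounds carry a hydrogen on this aromatic nitrogen, so they gave no reading of this position. In this assay, methyl in place of that hydrogen gives a 1.3-fold higher number from compound 3 to compound 4 (0.10 log units; within the scatter) and so stays within the scatter. The hydrogen on this nitrogen can therefore give way to a methyl without a measurable change in this assay, and nothing measured here explains why. Still open, from the compounds shown here alone, is how a longer chain, such as propyl, or a benzyl group on this nitrogen would read. Also open, going by these compounds, is whether methyl would behave the same way on compound 1 or compound 2.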